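A few compounds are considered here, and "the series" means these few. Any claim that something is new, unique, unknown or untested is made for them only; others in the source may bear on it.

Measured compounds:
compound 1 `C=CC(=O)Nc1cc(N)nc(Sc2c(OC)nc(N3CCCCC3)nc2OC)n1` – 9000 nM
compound 2 `C=CC(=O)Nc1cc(N)nc(Sc2c(OCC)nc(N3CCCCC3)nc2OCC)n1` – 7000 nM

In a functional assay on SK-BR-3 cells (Homo sapiens) for inhibition, read by resazurin assay, with a stated time of 72 h (on this read-out higher numbers stand for weaker inhibition and lower numbers for stronger inhibition), compound 1 gives 9000 nM, while compound 2 gives 7000 nM; the gap lies within the scatter, so the two cannot be ranked against each other, and both inhibit weakly. Compound 3 `C=CC(=O)Nc1cc(N)nc(Sc2c(OC)nc(N)nc2OC)n1` differs from compound 1 by amino in place of piperidin-1-yl on an aromatic carbon. Going by the values given here, no pair of measured compounds shows this change, so the step is untested. Given the weak numbers already seen, one expects a modest move toward weaker inhibition in this assay, only slightly beyond the scatter. For compound 3 the estimated value is 15000 nM, with a range of 5000 nM to 45000 nM, an expected step of a 1.7-fold higher number from compound 1 to compound 3 (0.22 log units; within the scatter).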

Compound 3, half-maximal inhibitory concentration: 3200 nM
Compound 3: middle estimate off by 4.7-fold (0.67 log units), on the high side; measured number outside the range, below it.
By their numbers in this assay, from the lowest: compound 3; then compounds 2 and 1 (each within the scatter of the next).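

In this assay, going by these compounds alone, the exchange of piperidin-1-yl for amino, on the aromatic carbon between two ring nitrogen atoms, gives a 2.8-fold lower number from compound 1 to compound 3 (0.45 log units; beyond the scatter) and is the first step here beyond the scatter. It shows that this position does not need the six-membered non-aromatic ring, as the much smaller amino group gives stronger inhibition. Nothing measured here explains the shift.

From the compounds shown here alone, it remains open whether amino itself matters or merely the absence of the ring, which methylamino, dimethylamino or morpholin-4-yl at this position could separate. Going by these compounds, whether ethoxy in place of methoxy behaves differently alongside amino also remains open.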